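This account rests on a few compounds, and the source may have more. Where it says the series, first, only, none or still open, it means among the compounds named here.

Compound 1 `COc1ccc2c(c1)NC(=O)CN2c1nc(Nc2cccc(C#N)c2)nc2ccccc12` gives 384 nM
Compound 2 `COc1ccc2c(c1)NC(=O)CN2c1nc(COCCCC(=O)NO)nc2ccccc12` gives 1210 nM
Compound 3 `COc1ccc2c(c1)NC(=O)CN2c1nc(NCc2ccncc2)nc2ccccc12` gives 71.8 nM

All three values come from a functional assay on MCF7 cells (Homo sapiens) for inhibition, read by sulforhodamine B assay, with a stated time of 48 h (a lower number here means a stronger inhibitor of growth, a higher number a weaker inhibitor of growth), and compound 3 has the lowest number of the set. It is reached by a 5.3-fold lower number from compound 1 to compound 3 (0.73 log units; beyond the scatter) and by a 17-fold lower number from compound 2 to compound 3 (1.23 log units; beyond the scatter), both beyond the scatter.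

Compound 4 `COc1ccc2c(c1)NC(=O)CN2c1nc(N2CC(OC)C2)nc2ccccc12` carries 3-methoxyazetidin-1-yl in place of ((pyridin-4-yl)methyl)amino on an aromatic carbon, between two ring nitrogen atoms 3-methoxyazetidin-1-yl in place of ((pyridin-4-yl)methyl)amino on an aromatic carbon at the same place that varies across the measured compounds.

The bearing steps are therefore a 5.3-fold lower number from compound 1 to compound 3 (0.73 log units; beyond the scatter) (modest) and a 17-fold lower number from compound 2 to compound 3 (1.23 log units; beyond the scatter) (large), along with a 3.2-fold higher number from compound 1 to compound 2 (0.50 log units; beyond the scatter) (modest). For the measured compounds named here, this place clearly matters, yet no measured compound has a four-membered ring there, so the data give no firm direction. No step beyond the scatter is expected in this assay, although a modest rise remains possible.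

The expected change is a 1.3-fold higher number from compound 3 to compound 4 (0.10 log units; within the scatter) as a central estimate only. For compound 4 the estimated value is 90 nM with an expected range from 20 nM to 400 nM in this assay.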

Compound 4, concentration for 50% growth inhibition: 8.6 nM
Estimate against measurement, compound 4: 10-fold (1.02 log units) above, and the stated range ends above it.
By their numbers in this assay, from the lowest: compound 4; then compound 3; then compound 1; then compound 2.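

In this assay, a four-membered non-aromatic ring on this aromatic carbon, between two ring nitrogen atoms, gives an 8.3-fold lower number from compound 3 to compound 4 (0.92 log units; beyond the scatter) as 3-methoxyazetidin-1-yl replaces ((pyridin-4-yl)methyl)amino, so this place accepts a smaller group with no aromatic ring and no hydrogen-bond donor and still gains in growth inhibition. The other two steps, a 45-fold lower number from compound 1 to compound 4 (1.65 log units; beyond the scatter) and a 140-fold lower number from compound 2 to compound 4 (2.15 log units; beyond the scatter), make compound 4 the most potent of the four, with all its steps beyond the scatter. Nothing shown here accounts for the size of these steps.

The compounds shown do not separate the share of the four-membered ring from that of its methoxy group. An unsubstituted azetidine, a 3-hydroxyazetidine or a morpholine at this place would bear on that question.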